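The source may hold more compounds than are shown below. What is called first, only, known or untested is meant among the compounds shown, and "the series" means these compounds.

Measured so far in an ADME assay on HEL cells (Homo sapiens) for cytotoxicity, with a stated time of 3 days; a lower number here means that less compound is tolerated, a higher number that more compound is tolerated:
- compound 1 `Cc1cc(-c2ccsc2)c2ncc(CSCc3ccccc3)n2c1` gives 100 ug/mL
- compound 2 `Cc1cc(-c2ccco2)c2ncc(CSCCc3ccccc3)n2c1` gives 41 ug/mL
- compound 3 `Cc1cc(N2CCCC2)c2ncc(CSCCc3ccccc3)n2c1` gives > 100 ug/mL

Compound 3 `Cc1cc(N2CCCC2)c2ncc(CSCCc3ccccc3)n2c1` stands at the top of the measured range in this assay, and its value of > 100 ug/mL is a limit of the assay rather than a number, as described in the limit of > 100 ug/mL in this assay, at which 1 of the 3 values shown sits. Among the compounds with values here, the only step measured in one place, an at least 2.4-fold higher number from compound 2 to compound 3 (0.38 log units; beyond the scatter), concerns the exchange of pyrrolidin-1-yl for furan-2-yl on an aromatic carbon and does not touch the chain on the sulfur.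

Compound 4 `Cc1cc(N2CCCC2)c2ncc(CSCc3ccccc3)n2c1` differs from compound 3 by phenyl in place of benzyl on a saturated chain carbon bound to a sulfur. Within the data shown here, no measured step isolates this change. Compound 1 and compound 2 differ both in this chain and in the ring on the aromatic carbon, so their values are only weak guidance. Compound 1 gives 100 ug/mL. Compound 2 gives 41 ug/mL. Both compounds are tolerated at or near the upper range. On that basis no change beyond the scatter is expected for compound 4 in this assay, and the step of a number no higher from compound 3 to compound 4 (the limit leaves the size open) is the expectation. Compound 4 is therefore estimated at 100 ug/mL, between 50 ug/mL and 200 ug/mL, most likely again reported only as a limit.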

Compound 4, half-maximal cytotoxic concentration: 52 ug/mL
For compound 4 the middle estimate is 1.9-fold (0.28 log units) above the measured one; measured number inside the range.
By their numbers in this assay, from the lowest: compounds 2, 4 and 1 (each within the scatter of the next, the first and the last beyond it).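

Within the data shown here, with the pyrrolidin-1-yl group held in place, this assay gives the first reading of the chain on the sulfur alone, phenyl in place of benzyl on a saturated chain carbon bound to a sulfur: an at least 1.9-fold lower number from compound 3 to compound 4 (0.28 log units; that floor lies within the scatter). From the compounds shown here alone, only a floor can be read from this step, and its true size stays open because compound 3 stands at a limit of the assay: the limit of > 100 ug/mL in this assay, at which 1 of the 4 values shown sits. With the benzyl chain held instead, the exchange on the aromatic carbon gives a 1.9-fold lower number from compound 1 to compound 4 (0.28 log units; within the scatter), so on this chain pyrrolidin-1-yl does not separate from thiophen-3-yl, although the earlier step from furan-2-yl, on the phenethyl chain, lay beyond the scatter.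

The compounds shown leave open whether the same change in the chain on the sulfur would read alike with furan-2-yl or thiophen-3-yl on the aromatic carbon. They also leave open how a morpholine ring on the aromatic carbon, or a longer chain ending in a carboxylic acid on the sulfur, would read in this assay.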